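The source may report more compounds than this note shows. Statements on the series, on what has been measured and on what is new or still open speak of the compounds shown alone.

Three compounds of one series have so far been run in a functional assay on KM12 cells (Homo sapiens) for cytotoxicity, read by sulforhodamine B assay, with a stated time of 48 h, tested at 0.1 uM; on this read-out higher numbers stand for a weaker effect at the one concentration tested and lower numbers for a stronger effect. Compound 1 `COc1cc(-c2cc(/C=C/C(=O)c3ccc(N)cc3)[nH]n2)cc(OC)c1OC` gives 98%, compound 2 `COc1cc(-c2cc(/C=C/C(=O)c3ccc(Cl)c(Cl)c3)[nH]n2)cc(OC)c1OC` gives 93%, and compound 3 `COc1ccc(C(=O)/C=C/c2cc(-c3cc(OC)c(OC)c(OC)c3)n[nH]2)cc1OC` gives 92%. Compound 3 holds the lowest of the three numbers, but the steps to it, a number 6 percentage points lower from compound 1 to compound 3 (within the scatter) and a number 1 percentage points lower from compound 2 to compound 3 (within the scatter), fall within the scatter, as does a number 5 percentage points lower from compound 1 to compound 2 (within the scatter). Every exchange on the carbonyl carbon has thus left this assay essentially unmoved. Compound 4 `COc1ccc(C(=O)/C=C/c2cc(-c3cc(OC)c(OC)c(OC)c3)n[nH]2)cc1` differs from compound 3 by hydrogen in place of methoxy on an aromatic carbon. Going by the values given here, no measured step removes a methoxy, so only the flat response to the earlier exchanges bears on the case. The step of a number 1 percentage points lower from compound 3 to compound 4 (within the scatter) is therefore expected to stay within the scatter. For compound 4 the estimated value is 91%, within the range 83% to 99%.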

Compound 4, a percentage reported as activity, at one concentration (the size of the read-out at that concentration, not a potency): 94%
Estimate against measurement, compound 4: 3 percentage points below, within the range that was stated.
By their numbers in this assay, from the lowest: compounds 3, 2, 4 and 1 (each within the scatter of the next).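

In this assay hydrogen in place of methoxy gives a number 2 percentage points higher from compound 3 to compound 4 (within the scatter) and thus extends the flat response from whole-ring exchanges to the loss of one methoxy from the 3,4-dimethoxyphenyl. The 4-methoxyphenyl compares no differently with the other groups on the carbonyl carbon, with a number 1 percentage points higher from compound 2 to compound 4 (within the scatter) and a number 4 percentage points lower from compound 1 to compound 4 (within the scatter) as its steps. Nothing available accounts for this flatness.

Whether a carboxylic acid or a longer chain such as butoxy on this aromatic carbon would move the number remains open, as does the behaviour of these compounds at any other concentration.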